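A Dichlorophenyl Variant Tested for Cytotoxicity

The compounds below may be only part of what the source reports. "The series", "measured", "known", "first", "only" and "open" are said of these compounds alone.

Compound 1 `COc1cc(-c2cc(/C=C/C(=O)c3ccc(N)cc3)[nH]n2)cc(OC)c1OC` was examined in a functional assay on SN12C cells (Homo sapiens) for cytotoxicity, read by sulforhodamine B assay, with a stated time of 48 h, tested at 100 uM; a higher number here means a weaker effect of the compound at the concentration tested, a lower number a stronger effect. In this assay compound 1 gives -86%. A related compound, compound 2 `COc1ccc(-c2cc(/C=C/C(=O)c3ccc(OC)c(OC)c3)[nH]n2)cc1`, was run in the same setting; in this assay compound 2 gives -86%. Compound 1 thus stands level with compound 2 at the digits reported, the two values lying within the usual scatter of each other, so neither can be called the stronger of the pair. Both show a strong effect at the concentration tested.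

Compound 3 `COc1cc(-c2cc(/C=C/C(=O)c3ccc(Cl)c(Cl)c3)[nH]n2)cc(OC)c1OC` has not yet been measured. It differs from compound 1 in one place: 3,4-dichlorophenyl in place of 4-aminophenyl on a carbonyl carbon. Among the measured compounds shown here, no measured step between compounds differing in one place is available, so the size of this exchange cannot be read from the data. For the measured compounds named here, the only guide is that compounds 1 and 2, with different aryl substitution, both gave a strong effect. The step of a number 6 percentage points higher from compound 1 to compound 3 (within the scatter) is therefore expected to be small, probably within the scatter. Compound 3 is estimated at -80% in this assay, with a range from -95% to -40%.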

Compound 3, a percentage reported as activity, at one concentration (the size of the read-out at that concentration, not a potency): 11%
Compound 3: the middle estimate sits 91 percentage points below what was measured; the whole stated range lies below it.
By their numbers in this assay, from the lowest: compounds 1 and 2 (each within the scatter of the next); then compound 3.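

Among the compounds shown here, the exchange of 4-aminophenyl for 3,4-dichlorophenyl on a carbonyl carbon gives, in this assay, a number 97 percentage points higher from compound 1 to compound 3 (beyond the scatter), and it is the first change in one place that can be read here. It shows that the effect at the concentration tested depends strongly on what this carbonyl carbon carries, something compounds 1 and 2 could not show, since they differ in more than one place and their equal values say nothing about any single group. Nothing at hand accounts for the size of this step, which therefore stands as an observation without an explanation.

The single exchange removes the 4-amino group and brings in two chlorines, so the compounds shown leave open which of these matters, a question that an unsubstituted phenyl, a 4-chlorophenyl or a 4-hydroxyphenyl on the same carbonyl carbon would help to settle. They also leave open whether the same exchange would produce a step of similar size on a core with a different pattern of methoxy groups.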